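The source may hold more compounds than are shown below. What is called first, only, known or untested is meant among the compounds shown, and "the series" means these compounds.

Compound 1 `CC(C)(C)[Si](C)(C)OC[C@H]1O[C@@H](n2ccc(N)nc2=O)[C@H](O[Si](C)(C)C(C)(C)C)[C@]12OS(=O)(=O)C=C2N` gives in a functional assay on MT4 cells (Homo sapiens) for cytotoxicity (on this read-out lower numbers stand for higher toxicity in this test and higher numbers for lower toxicity in this test), only a limit of the assay, > 360000 nM.
Compound 2 `CCn1c(=O)c(C)cn([C@@H]2O[C@H](CO[Si](C)(C)C(C)(C)C)[C@@]3(OS(=O)(=O)C=C3N)[C@H]2O[Si](C)(C)C(C)(C)C)c1=O` gives in this assay 123000 nM.

Compound 2 thus holds the only number shown; the other value is a limit. For the measured compounds named here, the one measured step, an at least 2.9-fold lower number from compound 1 to compound 2 (0.46 log units; beyond the scatter), exchanged the whole aromatic ring and rests on (the limit of > 360000 nM in this assay, at which 1 of the 2 values shown sits). Compound 3 `C=CCn1c(=O)ccn([C@@H]2O[C@H](CO[Si](C)(C)C(C)(C)C)[C@@]3(OS(=O)(=O)C=C3N)[C@H]2O[Si](C)(C)C(C)(C)C)c1=O` carries the change (a group of 11 heavy atoms (7 carbon, 2 nitrogen, 2 oxygen; one six-membered aromatic ring with 2 hetero atoms) in place of a group of 11 heavy atoms (7 carbon, 2 nitrogen, 2 oxygen; one six-membered aromatic ring with 2 hetero atoms), on a saturated ring carbon). Going by the values given here, no measured step swaps one such group for another of equal size, so that step bears little on it. Compound 3 is therefore expected to stay within the scatter, the expected step being a 1.0-fold lower number from compound 2 to compound 3 (0.01 log units; within the scatter). The estimate for compound 3 is 120000 nM, between 50000 nM and 300000 nM.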

Compound 3, half-maximal cytotoxic concentration: 8900 nM
Compound 3: middle estimate off by 13-fold (1.13 log units), on the high side; the measured number lies below the stated range.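

With the heavy atom count of the group on this saturated ring carbon unchanged, and its double bonds outside aromatic rings going from 2 to 3, the read-out still shows a 14-fold lower number from compound 2 to compound 3 (1.14 log units; beyond the scatter). So a change that leaves these counts nearly alike can move the number in this assay well beyond the scatter. The step from the group of 8 heavy atoms, an at least 40-fold lower number from compound 1 to compound 3 (1.60 log units; beyond the scatter), is bounded only by a limit of the assay: the limit of > 360000 nM in this assay, at which 1 of the 3 values shown sits.

The compounds shown leave open which part of the exchanged group carries this step. They also leave open how a longer chain or an amine in its place would read.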